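Dithiocarbamate phosphates on breast cancer cells: a paired step

The source may report more compounds than this note shows. Statements on the series, on what has been measured and on what is new or still open speak of the compounds shown alone.

In a functional assay on MDA-MB-231 cells (Homo sapiens) for inhibition, read by MTT assay, with stated times of 18 h and 4 h (a higher number here means a weaker inhibitor, a lower number a stronger inhibitor), compound 1 `CCCOP(=O)(O)OCCSC(=S)N1CCCCC1` gives 68000 nM, compound 2 `CCCCCCOP(=O)(O)OCCSC(=S)N1CCCCC1` gives 85000 nM and compound 3 `CCCCCCOP(=O)(O)OCCSC(=S)N1CCN(C)CC1` gives 73000 nM. All three numbers lie within the scatter of one another. The change from compound 2 to compound 1 is hydrogen in place of propyl on a saturated chain carbon, three bonds along the chain from an oxygen on an unsaturated carbon and gave a 1.3-fold lower number from compound 2 to compound 1 (0.10 log units; within the scatter). Compound 2 and compound 3 differ in their cores by 4-methylpiperazin-1-yl in place of piperidin-1-yl on a thiocarbonyl carbon, with a 1.2-fold lower number from compound 2 to compound 3 (0.07 log units; within the scatter). Compound 4 `CCCOP(=O)(O)OCCSC(=S)N1CCN(C)CC1` is not yet measured; it differs from compound 3 by hydrogen in place of propyl on a saturated chain carbon, three bonds along the chain from an oxygen on an unsaturated carbon, the same change made on the core of compound 3. Because a 1.3-fold lower number from compound 2 to compound 1 (0.10 log units; within the scatter) stayed within the scatter, compound 4 is expected to give a step of a 1.2-fold lower number from compound 3 to compound 4 (0.09 log units; within the scatter) in this assay. Compound 4 is therefore estimated at 60000 nM in this assay, between 35000 nM and 110000 nM.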

Compound 4, half-maximal inhibitory concentration: 62000 nM
The estimate for compound 4 lay 1.0-fold (0.01 log units) below the measured number, and the stated range covers the measured number.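

In this assay, the same exchange of hexyl for propyl on the second core gives a 1.2-fold lower number from compound 3 to compound 4 (0.07 log units; within the scatter). The change therefore carries from one core to the other with no difference that can be told apart: the same change on two cores in this assay, a 1.3-fold lower number (0.10 log units; within the scatter) from compound 2 to compound 1 and a 1.2-fold lower number (0.07 log units; within the scatter) from compound 3 to compound 4, 1.1-fold (0.03 log units) apart, within the scatter of two such steps

Within the data shown here, this shows only that the change stays within the scatter on both cores; it does not show that the chain length matters in this assay, or that the two cores would agree on a change with a larger step.

The compounds shown leave open whether a chain longer than hexyl, or a chain carrying a carboxylic acid, would give a step beyond the scatter in this assay. The same question stands for morpholin-4-yl in place of piperidin-1-yl on the thiocarbonyl carbon.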